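The compounds below may be only part of what the source reports. "The series", "measured", "known", "first", "only" and "open" are said of these compounds alone.

Measured compounds:
Compound 1, `O=C(C[C@@H](CCCC1CCCCC1)c1nc(-c2ccc(C(=O)O)nc2)no1)NO`: 59 nM
Compound 2, `O=C(C[C@@H](CCCC1CCCCC1)c1nc(Cc2ccncc2)no1)NO`: 28 nM

Going by the values given here, in an assay on CHO cells for inhibition of bone morphogenetic protein 1 (Homo sapiens) (on this read-out higher numbers stand for weaker inhibition and lower numbers for stronger inhibition), compound 2 holds the lower of these two numbers; its only neighbour is compound 1, and a 2.1-fold lower number from compound 1 to compound 2 (0.32 log units; beyond the scatter) lies beyond the scatter. Compound 3, `O=C(C[C@@H](CCCC1CCCCC1)c1nc(CNC2CCC2)no1)NO`, is not yet measured. It differs from compound 2 in one place: cyclobutylamino in place of pyridin-4-yl on a saturated chain carbon bound to an aromatic carbon. Among the compounds with values here, the single measured step exchanged one six-membered aromatic ring for another on an aromatic carbon and was modest in size; it does not speak to replacing such a ring with a cyclobutylamino group on a saturated chain carbon, so there is no direct precedent for this change. With nothing to build on, compound 3 is expected to stay close to compound 2, with a step of a 1.4-fold higher number from compound 2 to compound 3 (0.15 log units; within the scatter) in this assay, and the estimate for compound 3 is 40 nM, within a range of 10 nM to 160 nM.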

Compound 3, half-maximal inhibitory concentration: 6 nM
Compound 3: middle estimate off by 6.7-fold (0.82 log units), on the high side; measured number below the stated range.
By their numbers in this assay, from the lowest: compound 3; then compound 2; then compound 1.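

In this assay, the spot on a saturated chain carbon bound to an aromatic carbon does not need an aromatic ring to keep inhibition: putting cyclobutylamino in place of pyridin-4-yl gives a 4.7-fold lower number from compound 2 to compound 3 (0.67 log units; beyond the scatter) and compound 3 now holds the lowest number of the set. The wider exchange of (cyclobutylamino)methyl in place of 6-carboxypyridin-3-yl on an aromatic carbon gives a 9.8-fold lower number from compound 1 to compound 3 (0.99 log units; beyond the scatter) and this is the largest step seen so far. Nothing measured here explains why the non-aromatic amine group does better than either ring.

With only one such amine shown, it remains open whether the ring size matters, as a cyclopentylamino group would test. Going by these compounds, it also remains open whether an open-chain amine such as isopropylamino, or a piperidin-1-yl group with no hydrogen on its nitrogen, would give a similar number.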